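Sulfamoylurea series: swapping the aryl amide group

The source may hold more compounds than are shown below. What is called first, only, known or untested is meant among the compounds shown, and "the series" means these compounds.

Three compounds of the series carry a measurement in a functional assay on the whole organism (blood) with Rattus norvegicus as the target, with stated times of 24 h and 1 h, at a dose of 15 mg/kg by the intraperitoneal route; on this read-out lower numbers stand for a weaker effect and higher numbers for a stronger effect at the one dose given. Compound 2 `O=C(NC1CCCCC1)NS(=O)(=O)N1CCC(CCNC(=O)c2cccc3c2OCCO3)CC1` gives 42%. Compound 1 `Cn1cc(C(=O)NCCC2CCN(S(=O)(=O)NC(=O)NC3CCCCC3)CC2)c(=O)n(C)c1=O` gives 15%. Compound 3 `O=C(NC[C@@H]1C[C@@H]2C=C[C@@H]1C2)NS(=O)(=O)N1CCC(CCNC(=O)c2cccc3c2OCCO3)CC1` gives 40%. For the measured compounds named here, compound 4 `Cn1cc(C(=O)NCCC2CCN(S(=O)(=O)NC(=O)NC[C@@H]3C[C@@H]4C=C[C@@H]3C4)CC2)c(=O)n(C)c1=O` has no measurement yet in this assay.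

Compounds 2 and 1 differ in one place, (a group of 10 heavy atoms (6 carbon, 2 nitrogen, 2 oxygen; one six-membered aromatic ring with 2 hetero atoms) in place of a group of 10 heavy atoms (8 carbon, 2 oxygen; one six-membered non-aromatic ring with 2 hetero atoms, one six-membered aromatic ring of carbon only), on a carbonyl carbon). This change gave a number 27 percentage points lower from compound 2 to compound 1 (beyond the scatter). Compounds 2 and 3 differ in one place as well, (a group of 8 heavy atoms (8 carbon; 2 five-membered non-aromatic rings of carbon only) in place of a group of 6 heavy atoms (6 carbon; one six-membered non-aromatic ring of carbon only), on an amide-type nitrogen); this change gave a number 2 percentage points lower from compound 2 to compound 3 (within the scatter), so the two values are indistinguishable and no order between compound 2 and compound 3 is claimed.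

Compound 4 is related to compound 3 by a group of 10 heavy atoms (6 carbon, 2 nitrogen, 2 oxygen; one six-membered aromatic ring with 2 hetero atoms) in place of a group of 10 heavy atoms (8 carbon, 2 oxygen; one six-membered non-aromatic ring with 2 hetero atoms, one six-membered aromatic ring of carbon only), on a carbonyl carbon. The place of this change is described in the same words as for the pair of compound 2 and compound 1, so it is taken as the same change, carried out on a core that differs from the core of compound 2 only by the change that gave a number 2 percentage points lower from compound 2 to compound 3 (within the scatter). Going by the values given here, the one precedent rests on a single pair, and nothing shows whether the effect of the change depends on the group on the amide-type nitrogen.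

For compound 4 a step of about a number 26 percentage points lower from compound 3 to compound 4 (beyond the scatter) is expected, because the same change gave a number 27 percentage points lower from compound 2 to compound 1 (beyond the scatter) and the starting point of compound 3 is within the scatter of compound 2. Compound 4 is therefore estimated at 14%, with a range from 4% to 28% expected to cover most repeat measurements.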

Compound 4, a percentage reported as activity, at one dose (the size of the read-out at that dose, not a potency): 32%
Estimate against measurement, compound 4: 18 percentage points below; measured number outside the range, above it.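

On the core of compound 3, replacing the 2,3-dihydro-1,4-benzodioxin-5-yl group on the carbonyl carbon with the six-membered aromatic ring with 2 hetero atoms gave a number 8 percentage points lower from compound 3 to compound 4 (within the scatter) in this assay, so the step seen on the core of compound 2 did not carry over at the same size: the same change on two cores in this assay, a number 27 percentage points lower (beyond the scatter) from compound 2 to compound 1 and a number 8 percentage points lower (within the scatter) from compound 3 to compound 4, 19 percentage points apart, beyond the scatter of two such steps

The group on the amide-type nitrogen shows the same dependence, with a number 17 percentage points higher from compound 1 to compound 4 (beyond the scatter) in the presence of the incoming aromatic ring, whereas it made no distinguishable difference in the presence of the 2,3-dihydro-1,4-benzodioxin-5-yl group: the same change on two cores in this assay, a number 2 percentage points lower (within the scatter) from compound 2 to compound 3 and a number 17 percentage points higher (beyond the scatter) from compound 1 to compound 4, 19 percentage points apart, beyond the scatter of two such steps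

Both comparisons come from the same four compounds and amount to one observed interaction of the two changes, based on single pairs at one dose; they show that neither step can be transferred unchanged within this set, but not why, nor how either change would behave on any other core.

Going by these compounds, it remains open whether the interaction is particular to these two groups on the amide-type nitrogen or would also appear with a phenyl ring or a straight butyl chain there. Equally open, on these data alone, is whether a plain phenyl ring on the carbonyl carbon would follow the 2,3-dihydro-1,4-benzodioxin-5-yl group or the incoming aromatic ring.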